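Purine nucleoside series: swapping the benzyl substituent

The compounds below may be only part of what the source reports. "The series", "measured", "known", "first", "only" and "open" are said of these compounds alone.

Measured so far in a functional assay on G-361 cells (Homo sapiens) for antiproliferative activity, with a stated time of 72 h; a lower number here means a stronger inhibitor, a higher number a weaker inhibitor:
- compound 1, `OC[C@H]1O[C@@H](n2cnc3c(NCc4ccccc4Cl)ncnc32)[C@H](O)[C@@H]1O`: "not determined" (no result reported)
- compound 2, `Cc1cccc(CNc2ncnc3c2ncn3[C@@H]2O[C@H](CO)[C@@H](O)[C@H]2O)c1`: > 166000 nM
- compound 3, `OC[C@H]1O[C@@H](n2cnc3c(NCc4cccc(O)c4O)ncnc32)[C@H](O)[C@@H]1O`: 16900 nM

Going by the values given here, compound 3 holds the only actual number in this assay; one further entry is a limit and one has no result at all. For compound 2 the reported value is a limit of the assay, not a number. Among the compounds with values here, the one measured step, an at least 9.8-fold lower number from compound 2 to compound 3 (0.99 log units; beyond the scatter), is the sole direct evidence on how the aryl group bound to the chain carbon at the ring nitrogen affects the read-out.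

Compound 4, `OC[C@H]1O[C@@H](n2cnc3c(NCc4ccc(C(F)(F)F)cc4)ncnc32)[C@H](O)[C@@H]1O`, is the next entry. It differs from compound 3 in this way: 4-(trifluoromethyl)phenyl in place of 2,3-dihydroxyphenyl on a saturated chain carbon bound to a nitrogen on an aromatic ring. The incoming group carries neither donors nor acceptors, as the change spells out, which places it closer to compound 2 than to compound 3 in that respect. The step from compound 2 to compound 3 shows that going from a methylphenyl to the dihydroxyphenyl gave the only strong improvement seen, with compound 2 sitting at the limit of > 166000 nM in this assay, at which 1 of the 3 values shown sits. By that one comparison the loss of both hydroxyl groups in compound 4 is expected to move the number back up, though the size is uncertain with a single anchor.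

Compound 4 is therefore estimated at 100000 nM, between 20000 nM and 250000 nM, a step of a 5.9-fold higher number from compound 3 to compound 4 (0.77 log units; beyond the scatter) that is expected to lie beyond the scatter, with a real chance that only a limit is reported.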

Compound 4, half-maximal inhibitory concentration: > 166000 nM
Compound 4 ended at the assay's limit (the forecaster's own chance of this, stated with the estimate: 45%); middle value at least 1.6-fold (0.22 log units) from the limit.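

In this assay, placing 4-(trifluoromethyl)phenyl in place of 2,3-dihydroxyphenyl on the saturated chain carbon bound to a nitrogen on an aromatic ring gives an at least 9.8-fold higher number from compound 3 to compound 4 (0.99 log units; beyond the scatter), so the gain seen earlier is now bracketed by a second aryl group that loses it. Compound 2 and compound 4 both carry an aryl group with 0 hydrogen-bond donors and 0 hydrogen-bond acceptors, and both end at a limit rather than a number, so the earlier limit is no longer a single case: the limit of > 166000 nM in this assay, at which 2 of the 4 values shown sit. The steps between compound 2 and compound 4 cannot be read, since both entries are limits, and nothing orders 3-methylphenyl against 4-(trifluoromethyl)phenyl.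

With compound 3 the only entry holding a number, the compounds shown cannot tell whether both hydroxyl groups are needed or whether a phenyl carrying a single hydroxyl would keep a number in this assay. Also open, as far as these compounds go, is whether other groups on that phenyl, such as an amine or a carboxylic acid, would behave like the hydroxyl groups of compound 3 or give only a limit.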